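The compounds below may be only part of what the source reports. "The series", "measured", "known", "first", "only" and "open" are said of these compounds alone.

In a functional assay on Jurkat cells (Homo sapiens) (a lower number here means a stronger inhibitor, a higher number a weaker inhibitor), compound 1 (`CC(C)[C@H](NC(=O)COc1cccc2ccccc12)C(=O)N[C@@H](CC(=O)O)C(=O)COc1ccc(F)cc1F`) gives 33200 nM. Compound 2 (`CC(C)[C@H](NC(=O)COc1cccc2ccccc12)C(=O)N[C@@H](CC(=O)O)C(=O)COc1cc(F)cc(F)c1`) reads > 100000 nM, which is a limit of the assay and not a number. Compound 3 (`CC(C)[C@H](NC(=O)COc1cccc2ccccc12)C(=O)N[C@@H](CC(=O)O)C(=O)COc1c(F)c(F)cc(F)c1F`) follows from compound 2 through one change: 2,3,5,6-tetrafluorophenyl in place of 3,5-difluorophenyl on an oxygen on a saturated carbon. For the measured compounds named here, one measured step bears on this, an at least 3.0-fold higher number from compound 1 to compound 2 (0.47 log units; beyond the scatter), and it shows that the number in this assay responds to the fluorine pattern on this phenyl alone. A sizeable move to a lower number is therefore expected, though with wide uncertainty. The expected change is an at least 16-fold lower number from compound 2 to compound 3 (1.22 log units; beyond the scatter). For compound 3 the estimated value is 6000 nM, with an expected range of 400 nM to 60000 nM.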

Compound 3, half-maximal inhibitory concentration: 4500 nM
For compound 3 the middle estimate is 1.3-fold (0.12 log units) above the measured one; measured number inside the range.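

In this assay, the 2,3,5,6-tetrafluorophenyl group gives an at least 22-fold lower number from compound 2 to compound 3 (1.34 log units; beyond the scatter) and a 7.4-fold lower number from compound 1 to compound 3 (0.87 log units; beyond the scatter), so this position can carry a far stronger inhibitor than either difluorophenyl group allowed, and compound 3 is the strongest of the three. More fluorine atoms on this phenyl go with a lower number here, but compound 1 and compound 2 carry the same count and still differ. Compound 2 stands at a limit of the assay, not a number: the limit of > 100000 nM in this assay, at which 1 of the 3 values shown sits.

From the compounds shown here alone, how an unsubstituted phenyl or a pentafluorophenyl would read at this position remains open. So does whether a chloro or methoxy group on this ring would behave like fluorine.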